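The compounds below may be only part of what the source reports. "The series", "measured", "known", "first", "only" and "open" are said of these compounds alone.

Compound 1, whose structure is `CCN1CCN(c2cc(C)c3cc(NC(=O)c4ccc(F)cc4)ccc3n2)CC1`, was tested in a functional assay on SK-BR-3 cells (Homo sapiens) for antiproliferative activity, read by MTT assay, with a stated time of 72 h (a lower number here means a stronger inhibitor, a higher number a weaker inhibitor), where compound 1 gives 19800 nM. Two close relatives were measured alongside it. Compound 2, `CCc1ccccc1C(=O)Nc1ccc2nc(N3CCN(CC)CC3)cc(C)c2c1`, gives 23900 nM in this assay, and compound 3, `CCN1CCN(c2cc(C)c3cc(NC(=O)c4ccc(Cl)cc4)ccc3n2)CC1`, gives 3020 nM. Among these three numbers compound 1 stands second highest: its nearest neighbour is compound 2, reached by a 1.2-fold higher number from compound 1 to compound 2 (0.08 log units; within the scatter), while its furthest is compound 3, reached by a 6.6-fold lower number from compound 1 to compound 3 (0.82 log units; beyond the scatter). Compound 4, `CCN1CCN(c2cc(C)c3cc(NC(=O)c4cccc(F)c4)ccc3n2)CC1`, has not yet been measured. It differs from compound 1 in one respect: 3-fluorophenyl in place of 4-fluorophenyl on a carbonyl carbon. Among the measured compounds shown here, no measured step moves a fluorine within the same phenyl ring, so the closest guides are the steps that alter the group on the carbonyl carbon, namely a 1.2-fold higher number from compound 1 to compound 2 (0.08 log units; within the scatter) and a 7.9-fold lower number from compound 2 to compound 3 (0.90 log units; beyond the scatter), together with a 6.6-fold lower number from compound 1 to compound 3 (0.82 log units; beyond the scatter). These show that swapping the whole group or the halogen shifts this assay only modestly or not at all, so a step within the scatter is expected for a 1.0-fold higher number from compound 1 to compound 4 (0.00 log units; within the scatter). Compound 4 is therefore estimated at 20000 nM, within a range from 6000 nM to 60000 nM.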

Compound 4, half-maximal inhibitory concentration: 24900 nM
Compound 4: middle estimate off by 1.2-fold (0.10 log units), on the low side, within the range that was stated.
By their numbers in this assay, from the lowest: compound 3; then compounds 1, 2 and 4 (each within the scatter of the next).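

In this assay, moving the fluorine, 3-fluorophenyl in place of 4-fluorophenyl on a carbonyl carbon, gives a 1.3-fold higher number from compound 1 to compound 4 (0.10 log units; within the scatter) and so leaves no readable change. Compound 4 also sits level with the bulkier-looking swap, with a 1.0-fold higher number from compound 2 to compound 4 (0.02 log units; within the scatter) as the step, so three quite different groups on this carbonyl carbon give matching numbers. Against these, 4-chlorophenyl remains the exception, with an 8.2-fold higher number from compound 3 to compound 4 (0.92 log units; beyond the scatter) marking compound 3 as the most potent of the four, and this shows that a halogen on the ring does not by itself bring the lower number, since the fluorine gives no such drop at either ring position shown.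

Still open, as far as these compounds go, is whether the lower number belongs to chloro alone or would also come with bromo, methyl or an amine on the same ring. Nothing given here explains why these numbers fall as they do.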